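This account rests on a few compounds, and the source may have more. Where it says the series, first, only, none or still open, it means among the compounds named here.

Measured compounds:
compound 1 `O=C1NC(=S)S/C1=C\C=C\c1ccccc1OCc1ccccc1Br` gives 63.1%
compound 2 `O=C1NC(=S)S/C1=C\C=C\c1ccccc1OCc1ccncc1` gives 39.4%
compound 3 `Cc1ccccc1COc1ccccc1/C=C/C=C1\SC(=S)NC1=O` gives 52.8%

In an assay on isolated protein for inhibition of protein tyrosine phosphatase type IVA 3 (Homo sapiens), tested at 5 ug/mL (on this read-out lower numbers stand for less inhibition and higher numbers for more inhibition at the one concentration tested (going by the name of the read-out)), compound 1 stands highest of the three, with compound 3 nearest and compound 2 furthest away: the steps of a number 10.3 percentage points lower from compound 1 to compound 3 (beyond the scatter) and a number 23.7 percentage points lower from compound 1 to compound 2 (beyond the scatter) both lie beyond the scatter, as does a number 13.4 percentage points higher from compound 2 to compound 3 (beyond the scatter). Compound 4 `O=C1NC(=O)/C(=C/C=C/c2ccccc2OCc2ccccc2Br)S1` differs from compound 1 at the five-membered ring of the core: a group of 8 heavy atoms (4 carbon, 1 nitrogen, 2 oxygen, 1 sulfur; one five-membered non-aromatic ring with 2 hetero atoms) in place of a group of 8 heavy atoms (4 carbon, 1 nitrogen, 1 oxygen, 2 sulfur; one five-membered non-aromatic ring with 2 hetero atoms), on a double-bonded chain carbon bound to a double-bonded chain carbon. Among the compounds with values here, no measured step touches that ring; all three steps change only the group on the saturated chain carbon bound to the oxygen on the aromatic ring, and they are modest in size. Without a step bearing on the core change, compound 4 is expected to fall somewhat, by a number 18.1 percentage points lower from compound 1 to compound 4 (beyond the scatter). Compound 4 is therefore estimated at 45%, within 20% to 65%.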

Compound 4, a percentage reported as inhibition, at one concentration (the size of the read-out at that concentration, not a potency): 22.5%
Compound 4: the middle estimate sits 22.5 percentage points above what was measured; measured number inside the range.
By their numbers in this assay, from the lowest: compound 4; then compound 2; then compound 3; then compound 1.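

Exchanging the sulfur-richer group for the oxygen-richer one, on a double-bonded chain carbon bound to a double-bonded chain carbon, leaves the counts of heavy atoms, donors and acceptors unchanged, yet it gives a number 40.6 percentage points lower from compound 1 to compound 4 (beyond the scatter). Within the data shown here, that is a larger move than a number 23.7 percentage points lower from compound 1 to compound 2 (beyond the scatter), the largest step among the earlier compounds, so this position counts for more than those changes did. Nothing available explains the drop.

From the compounds shown here alone, whether the same exchange costs as much alongside pyridin-4-yl or 2-methylphenyl stays open. So does the effect of a group carrying a carboxylic acid at this place.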